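A Benzyl Group Replaces a Pentenyl Chain

A few compounds are considered here, and "the series" means these few. Any claim that something is new, unique, unknown or untested is made for them only; others in the source may bear on it.

Three measured compounds share a common core and differ in the group carried on the sulfur or on the aromatic ring. Compound 1 `C=CCCSC[C@H](NC(=O)c1cc(OC)c(OC)c(OC)c1)C(=O)OC` gives 27300 nM in an assay on RAW264.7 cells for antagonist activity at Toll-like receptor 2 (Mus musculus), read by Griess assay, with a stated time of 24 h; a lower number here means a stronger inhibitor, a higher number a weaker inhibitor. Compound 2 `C=CCSC[C@H](NC(=O)c1cc(O)c(O)c(O)c1)C(=O)OC` gives 52100 nM in this assay, and compound 3 `C=CCCCSC[C@H](NC(=O)c1cc(O)c(O)c(O)c1)C(=O)OC` gives 39200 nM. Compound 3 stands second highest of the three numbers, but its gaps to compound 2 and to compound 1 are both within the scatter, so no order among the three can be read from them.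

Compound 4 `COC(=O)[C@H](CSCc1ccccc1)NC(=O)c1cc(O)c(O)c(O)c1` carries phenyl in place of but-3-en-1-yl on a saturated chain carbon bound to a sulfur. Among the measured compounds shown here, the only single-site step measured is a 1.3-fold lower number from compound 2 to compound 3 (0.12 log units; within the scatter), a change in the same chain that left the number essentially where it was. Compound 1 differs from compound 3 in two places, so its value alone cannot be tied to the chain. Nothing measured speaks directly to an aromatic ring at this position. The step from compound 3 to compound 4 is therefore expected to be small, a 1.3-fold lower number from compound 3 to compound 4 (0.12 log units; within the scatter), with no direction beyond the scatter. Compound 4 is estimated at 30000 nM, with a range from 10000 nM to 90000 nM.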

Compound 4, half-maximal inhibitory concentration: 60700 nM
For compound 4 the middle estimate is 2.0-fold (0.31 log units) below the measured one; the measured number falls inside the stated range.
By their numbers in this assay, from the lowest: compounds 1, 3, 2 and 4 (each within the scatter of the next, the first and the last beyond it).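

On a saturated chain carbon bound to a sulfur, a ring can now be compared with the open chains. In this assay, phenyl in place of but-3-en-1-yl gives (in the words of the step) a 1.5-fold higher number from compound 3 to compound 4 (0.19 log units; within the scatter) and phenyl in place of vinyl gives a 1.2-fold higher number from compound 2 to compound 4 (0.07 log units; within the scatter), so this place accepts a six-membered aromatic ring of carbon only with no change that can be told from the scatter of repeated measurements, and the three groups cannot be ranked. Nothing is at hand that would explain this result.

As far as these compounds go, it remains open whether a phenyl ring carrying a methoxy group or a hydroxyl group would give a number beyond the scatter. The same question stands for an amine or a carboxylic acid at the end of the chain.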